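The source may report more compounds than this note shows. Statements on the series, on what has been measured and on what is new or still open speak of the compounds shown alone.

Measured compounds:

Compound 1, `COc1ccc(N2CCN(C(=S)SCc3ccc(C(=O)Nc4ccccc4N)cc3)CC2)cc1`: 39.4%
Compound 2, `Nc1ccccc1NC(=O)c1ccc(CSC(=S)N2CCN(c3ccc(F)cc3)CC2)cc1`: 60.8%
Compound 3, `Nc1ccccc1NC(=O)c1ccc(CSC(=S)N2CCN(Cc3ccncc3)CC2)cc1`: 59.5%

All three share a core and differ only in the group on the amine nitrogen in the ring. In a functional assay on HeLa cells (Homo sapiens) for antiproliferative activity, read by CCK-8 assay, with a stated time of 72 h, tested at 2 uM (a lower number here means a weaker effect, a higher number a stronger effect of the compound at the concentration tested), compound 3 stands second highest of the three numbers. Its nearest neighbour is compound 2, and the two are within scatter of each other, as the step of a number 1.3 percentage points lower from compound 2 to compound 3 (within the scatter) shows. The furthest is compound 1, and the step of a number 20.1 percentage points higher from compound 1 to compound 3 (beyond the scatter) lies beyond the scatter.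

Compound 4, `Nc1ccccc1NC(=O)c1ccc(CSC(=S)N2CCN(Cc3cccnc3)CC2)cc1`, has not yet been measured. It differs from compound 3 in one place:

pyridin-3-yl in place of pyridin-4-yl on a saturated chain carbon bound to an amine nitrogen in a ring

Among the compounds with values here, no measured step swaps one pyridinyl group for another, so nothing bears on this change directly. The measured steps touching the same region are a number 21.4 percentage points higher from compound 1 to compound 2 (beyond the scatter) and a number 20.1 percentage points higher from compound 1 to compound 3 (beyond the scatter), both modest, and a number 1.3 percentage points lower from compound 2 to compound 3 (within the scatter), within the scatter, which shows that exchanging two rather different groups at this place left the number unchanged. A swap that keeps the same atoms and only joins them differently is expected to produce no step beyond the scatter in this assay, so the expected step is a number 1.5 percentage points lower from compound 3 to compound 4 (within the scatter).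

Compound 4 is therefore estimated to give 58% in this assay, with a range from 45% to 70%.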

Compound 4, a percentage reported as inhibition, at one concentration (the size of the read-out at that concentration, not a potency): 69.7%
The estimate for compound 4 lay 11.7 percentage points below the measured number; the measured number falls inside the stated range.
By their numbers in this assay, from the lowest: compound 1; then compounds 3, 2 and 4 (each within the scatter of the next, the first and the last beyond it).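

Swapping pyridin-4-yl for pyridin-3-yl in this assay keeps the same atoms and only joins them differently, yet it gives a number 10.2 percentage points higher from compound 3 to compound 4 (beyond the scatter) and not a step lost in the noise, so this position can register a change as small as how the pyridine ring is attached. Within the data shown here, the earlier compounds could not show this, since the only comparison among them that did not involve compound 1 was a swap of two quite different groups with a number 1.3 percentage points lower from compound 2 to compound 3 (within the scatter) as its outcome. The new compound also gives a number 8.9 percentage points higher from compound 2 to compound 4 (within the scatter) and a number 30.3 percentage points higher from compound 1 to compound 4 (beyond the scatter), which leaves the 4-methoxyphenyl group of compound 1 well apart from the other three, while nothing available explains why the two pyridinyl groups differ.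

What the compounds shown leave open is how pyridin-2-yl would compare with its two relatives, and whether a longer chain in place of the single carbon linking the pyridine ring would keep the number where it is. These read-outs also come from one concentration in one cell line, so they give the size of the effect at that concentration and not a potency.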